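Methoxy on the saturated ring of a phenylethynyl pyridine

The compounds below may be only part of what the source reports. "The series", "measured", "known", "first", "only" and "open" are said of these compounds alone.

Three close relatives of one shared core have been measured in an assay on isolated protein for displacement of a labelled ligand from metabotropic glutamate receptor 5 (Rattus norvegicus); a higher number here means a weaker inhibitor, a lower number a stronger inhibitor. Compound 1 `O[C@H]1CCCc2nc(C#Cc3ccccc3)ccc21` carries a hydroxy on a saturated ring carbon and gives 9280 nM. Compound 2 `O=C1CCCc2nc(C#Cc3ccccc3)ccc21`, with a carbonyl at that ring, gives 800 nM. Compound 3 `C(#Cc1ccc2c(n1)CCCC2)c1ccccc1`, bearing only hydrogen there, gives 1500 nM, which places it second highest of the three numbers: it lies within the scatter of compound 2, and a 6.2-fold lower number from compound 1 to compound 3 (0.79 log units; beyond the scatter).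

Compound 4 `COC1CCCc2nc(C#Cc3ccccc3)ccc21` is the next step: methoxy in place of hydrogen on a saturated ring carbon. Going by the values given here, the one measured step that bears on it is the hydroxy-to-hydrogen step from compound 1 to compound 3, a modest drop; read backwards, placing an oxygen-bearing group on that saturated ring carbon raised the number. Methoxy is not hydroxy, so the same size cannot be assumed, but a rise beyond the scatter is the more likely outcome. Compound 4 is therefore expected to give 3500 nM in this assay, with a range from 1200 nM to 10000 nM, an expected step of a 2.3-fold higher number from compound 3 to compound 4 (0.37 log units; beyond the scatter).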

Compound 4, inhibition constant: 139 nM
Beside the measured number, compound 4's estimate is 25-fold (1.40 log units) above it, and the stated range ends above it.
By their numbers in this assay, from the lowest: compound 4; then compounds 2 and 3 (each within the scatter of the next); then compound 1.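

Placing methoxy in place of hydrogen on this saturated ring carbon gives an 11-fold lower number from compound 3 to compound 4 (1.03 log units; beyond the scatter) in this assay, so this carbon can carry a substituent and the number still falls. An oxygen-bearing group there does not always raise the number: compound 1, with hydroxy on the same carbon, gives 9280 nM in this assay, whereas compound 4 gives 139 nM and the identity of the group clearly matters. No measurement available here explains why methoxy and hydroxy part so widely.

Going by these compounds, whether a longer chain such as ethoxy, or an amine on the same carbon, would keep the number this low remains open. Compound 1 is drawn as a single mirror-image form and compound 4 is not, so the effect of spatial arrangement at this carbon also remains unsettled.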